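This account rests on a few compounds, and the source may have more. Where it says the series, first, only, none or still open, it means among the compounds named here.

In an ADME assay for protein binding, using equilibrium dialysis, at pH 7.4, tested at 2 uM (on this read-out higher numbers stand for a larger free fraction and lower numbers for a smaller free fraction), compound 1 `CC(C)N(c1cc(C#CC(C)(C)C)sc1C(=O)O)C(=O)[C@H]1CC[C@H](C)CC1` gives 0.06 and compound 2 `CON=C1CCC(N(c2cc(C#CC(C)(C)C)sc2C(=O)O)C(=O)[C@H]2CC[C@H](C)CC2)CC1` gives 0.07 and these two numbers lie within the scatter of each other. Compound 3 `CC(C)(C)C#Cc1cc(N(CCO)C(=O)[C@H]2CC[C@H](C)CC2)c(C(=O)O)s1` reads "not determined" (no result reported) and adds no number. Compound 4 `CC(C)N(C(=O)[C@H]1CC[C@@H]2C[C@@H]2CC1)c1cc(C#CC(C)(C)C)sc1C(=O)O` departs from compound 1 on a carbonyl carbon, where the change is a group of 8 heavy atoms (8 carbon; one three-membered non-aromatic ring of carbon only, one seven-membered non-aromatic ring of carbon only) in place of a group of 7 heavy atoms (7 carbon; one six-membered non-aromatic ring of carbon only), on a carbonyl carbon and 4-methylcyclohexyl leaves. Neither group carries a net charge. Within the data shown here, no measured step touches that place. Among the measured compounds shown here, the only step available, a 1.2-fold higher number from compound 1 to compound 2 (0.07 log units; within the scatter) on an amide-type nitrogen, offers indirect support at best. For the measured compounds named here, with that step as the sole guide, no change beyond the scatter is expected in this assay and the expected 1.2-fold lower number from compound 1 to compound 4 (0.08 log units; within the scatter) stays small. Compound 4 is expected at 0.05 within an estimated range from 0.03 to 0.09 for this measurement.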

Compound 4, unbound fraction: 0.08
Beside the measured number, compound 4's estimate is 1.6-fold (0.20 log units) below it; the measured number falls inside the stated range.
By their numbers in this assay, from the lowest: compounds 1, 2 and 4 (each within the scatter of the next).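

The carbonyl carbon now has a measured step of its own: exchanging 4-methylcyclohexyl for the all-carbon group with a three-membered and a seven-membered ring gives a 1.3-fold higher number from compound 1 to compound 4 (0.12 log units; within the scatter) in this assay. At this place, then, an exchange between two uncharged groups without hydrogen-bond donors or acceptors stays within the scatter. No available measurement bears on the reason for this result. Both groups compared here contain carbon only. On these data alone, whether an amine or a carboxylic acid in the group on the carbonyl carbon would move the unbound fraction beyond the scatter remains open.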